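The source may report more compounds than this note shows. Statements on the series, on what has been measured and on what is new or still open speak of the compounds shown alone.

Compound 3 `CCCCCCCNC(=O)[C@H]1OC(n2cnc3c(N)ncnc32)[C@H](O)[C@@H]1O` stands second highest of the three numbers in an assay on cell membranes for binding affinity to 2-oxoglutarate receptor 1 (Rattus norvegicus), read by radioligand binding; on this read-out higher numbers stand for weaker inhibition and lower numbers for stronger inhibition: compound 3 gives 20 nM, whereas compound 1 `NC(=O)[C@H]1OC(n2cnc3c(N)ncnc32)[C@H](O)[C@@H]1O` gives 64 nM. Compound 2 `CCCCCNC(=O)[C@H]1O[C@@H](n2cnc3c(N)ncnc32)[C@H](O)[C@@H]1O` gives 12 nM, and the values of compound 2 and compound 3 lie within the scatter of each other. Within the data shown here, the only single-point step available, a 3.2-fold lower number from compound 1 to compound 3 (0.51 log units; beyond the scatter), concerns chain growth at the amide-type nitrogen. Compound 4 `CCCCCCCCCCCNC(=O)[C@H]1OC(n2cnc3c(N)ncnc32)[C@H](O)[C@@H]1O` differs from compound 3 by butyl in place of hydrogen on a saturated chain carbon, seven bonds along the chain from an amide-type nitrogen. Among the measured compounds shown here, no measured step covers chain growth beyond heptyl, and the pair compound 2 and compound 3 shows no separation beyond the scatter. A step of a 1.3-fold higher number from compound 3 to compound 4 (0.10 log units; within the scatter) is therefore expected for compound 4 in this assay, not beyond the scatter. The estimate for compound 4 is 25 nM, range 8 nM to 80 nM.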

Compound 4, inhibition constant: 123 nM
Beside the measured number, compound 4's estimate is 4.9-fold (0.69 log units) below it, outside the stated range (above it).
By their numbers in this assay, from the lowest: compounds 2 and 3 (each within the scatter of the next); then compounds 1 and 4 (each within the scatter of the next).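

Butyl in place of hydrogen on a saturated chain carbon, seven bonds along the chain from an amide-type nitrogen, gives a 6.2-fold higher number from compound 3 to compound 4 (0.79 log units; beyond the scatter) in this assay. This runs against a 3.2-fold lower number from compound 1 to compound 3 (0.51 log units; beyond the scatter), so among these compounds lengthening the chain on this nitrogen does not keep lowering the number. No measured evidence here accounts for this reversal. Open, from the compounds shown here alone, is where between heptyl and the longer chain of compound 4 the turn lies, and how a chain ending in an amine or a carboxylic acid would read.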